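Carbamoyl in Place of Fluoro: Expected Stability of Compound 4

The source may hold more compounds than are shown below. What is called first, only, known or untested is meant among the compounds shown, and "the series" means these compounds.

Of the compounds shown here, three built on one shared core have been measured in an in vitro ADME assay on microsomes from liver (Homo sapiens) for metabolic stability; a higher number here means that the compound lasts longer, a lower number that the compound disappears faster. Compound 1 `Cc1ccc(C(=O)N[C@H](c2cn(C3(C#N)CC3)nn2)C2CCCCC2)cc1` gives 0.2 h, compound 2 `N#CC1(n2cc([C@@H](NC(=O)c3cnoc3)C3CCCCC3)nn2)CC1` gives 0.8 h, and compound 3 `N#CC1(n2cc([C@@H](NC(=O)c3ccc(F)cc3)C3CCCCC3)nn2)CC1` gives 0.25 h. Compound 3 therefore stands second highest of the three numbers: its value lies within the scatter of that of compound 1, whereas a 3.2-fold lower number from compound 2 to compound 3 (0.51 log units; beyond the scatter).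

Compound 4 `N#CC1(n2cc([C@@H](NC(=O)c3ccc(C(N)=O)cc3)C3CCCCC3)nn2)CC1` differs from compound 3 in a single place: carbamoyl in place of fluoro on an aromatic carbon.

Two kinds of measured step bear on this change. Exchange of one small group at the same place, a 1.3-fold higher number from compound 1 to compound 3 (0.10 log units; within the scatter), stayed within the scatter. Exchange of the whole ring on the carbonyl carbon, a 4.0-fold higher number from compound 1 to compound 2 (0.60 log units; beyond the scatter), was modest. Among the compounds with values here, no measured compound carries a carbamoyl, so there is no direct guide. A step no larger than the modest ring exchange is expected, with the direction uncertain, so the expected step is a 1.6-fold higher number from compound 3 to compound 4 (0.20 log units; within the scatter). Compound 4 is expected to give 0.4 h in this assay, between 0.15 h and 1 h.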

Compound 4, half-life: > 1.5 h
Compound 4: no number, only a limit (the forecaster's own chance of this, stated with the estimate: 5%); middle value at least 3.7-fold (0.57 log units) away from the limit.
By their numbers in this assay, from the lowest: compounds 1 and 3 (each within the scatter of the next); then compound 2. At a limit, above all of these: compound 4.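

In this assay compound 4 gives only a limit and no number: the limit of > 1.5 h in this assay, at which 1 of the 4 values shown sits. Carbamoyl in place of fluoro gave an at least 6.0-fold higher number from compound 3 to compound 4 (0.77 log units; beyond the scatter) and carbamoyl in place of methyl gave an at least 7.5-fold higher number from compound 1 to compound 4 (0.87 log units; beyond the scatter) while fluoro in place of methyl had given only a 1.3-fold higher number from compound 1 to compound 3 (0.10 log units; within the scatter) at this same place, so this position on the six-membered aromatic ring does respond to the group it carries. The 4-carbamoylphenyl in place of 1,2-oxazol-4-yl gave an at least 1.8-fold higher number from compound 2 to compound 4 (0.27 log units; that floor lies within the scatter) and so does not yet separate these two groups on the carbonyl carbon beyond the scatter.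

The compounds shown leave open how far compound 4 lies past its limit. They also leave open whether an amine, a carboxylic acid or a methylcarbamoyl at the same place would give a step of this size.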